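Swapping the Halogenated Ring on a Shared Core

The compounds below may be only part of what the source reports. "The series", "measured", "known", "first", "only" and "open" are said of these compounds alone.

Compound 1 `COc1cc(OC)c(C(=O)c2cccc(Cl)c2)c(O)c1CN1CCCCC1` gives 33% in a functional assay on THP-1 cells (Homo sapiens) for inhibition, read by ELISA, with stated times of 30 min and 24 h, tested at 1 uM (a lower number here means a weaker effect, a higher number a stronger effect of the compound at the concentration tested), the top of the three numbers recorded, though compound 3 sits within the scatter of it. Compound 3 `COc1cc(O)c(C(=O)c2cccc(Cl)c2)c(OC)c1` gives 31%, and the step of a number 2 percentage points lower from compound 1 to compound 3 (within the scatter) shows that the (piperidin-1-yl)methyl group hardly changes the read-out. Compound 2 `COc1cc(OC)c(C(=O)c2ccccc2F)c(O)c1CN1CCCC1` gives 15%, beyond the scatter below compound 1, but it differs from compound 1 in two places, so no single measured step accounts for that gap.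

Compound 4 `COc1cc(OC)c(C(=O)c2ccccc2Br)c(O)c1CN1CCCCC1` brings the change (2-bromophenyl in place of 3-chlorophenyl on a carbonyl carbon). Among the compounds with values here, no measured step tests this swap on its own, so the expectation rests on the lower number of compound 2, which also carries a different halogenated ring, while the only clean step recorded is within the scatter. A modest fall is expected, a number 11 percentage points lower from compound 1 to compound 4 (beyond the scatter). Compound 4 is expected to give about 22%, between 5% and 40%.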

Compound 4, a percentage reported as activity, at one concentration (the size of the read-out at that concentration, not a potency): 22%
Compound 4: the middle estimate sits on the measured number at the digits printed; the range from low to high includes it.
By their numbers in this assay, from the lowest: compounds 2, 4, 3 and 1 (each within the scatter of the next, the first and the last beyond it).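

Putting 2-bromophenyl in place of 3-chlorophenyl gives a number 11 percentage points lower from compound 1 to compound 4 (beyond the scatter) while a number 2 percentage points lower from compound 1 to compound 3 (within the scatter) comes from removing the (piperidin-1-yl)methyl group. In this assay the ring on the carbonyl carbon is therefore a place where one change alone moves the read-out beyond the scatter. No measurement here explains why this swap lowers the number.

The swap changes both the halogen and where it sits on the ring, so these two changes cannot yet be separated; 2-chlorophenyl or 3-bromophenyl would pull them apart. From the compounds shown here alone, whether plain phenyl, with no halogen, would keep the read-out remains open.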